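Thiophen-2-yl to thiophen-3-yl in the series

The source may hold more compounds than are shown below. What is called first, only, known or untested is meant among the compounds shown, and "the series" means these compounds.

Measured so far in a functional assay on HeLa cells (Homo sapiens) for inhibition, with a stated time of 72 h; a higher number here means a weaker inhibitor, a lower number a stronger inhibitor:
- compound 1 `NC1CCC(Nc2nc(NCc3ccc(-c4cccc(F)c4)nc3)c3ncn(C4CCCC4)c3n2)CC1` gives 36 nM
- compound 2 `NC1CCC(Nc2nc(NCc3ccc(-c4cccs4)nc3)c3ncn(C4CCCC4)c3n2)CC1` gives 40 nM

Within the data shown here, compound 2 stands at 40 nM on a scale of only two numbers, and its sole neighbour is compound 1. Compound 3 `NC1CCC(Nc2nc(NCc3ccc(-c4ccsc4)nc3)c3ncn(C4CCCC4)c3n2)CC1` is the next to be read. Its difference from compound 2 is thiophen-3-yl in place of thiophen-2-yl on an aromatic carbon and the two have the same atoms, joined differently. The exchange is thiophen-3-yl in place of thiophen-2-yl on an aromatic carbon, next to the ring nitrogen.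

Among the measured compounds shown here, no measured pair covers this exchange directly. For the measured compounds named here, the only step bearing on it is at the same place, where 3-fluorophenyl gives way to thiophen-2-yl, and it amounts to a 1.1-fold higher number from compound 1 to compound 2 (0.05 log units; within the scatter) in this small set. One step is thin evidence, but it gives no reason to expect a shift in either direction in this assay beyond the scatter. The expected change is no change at the digits printed from compound 2 to compound 3 (within the scatter) in this estimate. For compound 3 the estimated value is 40 nM with an expected range of 18 nM to 90 nM in this assay.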

Compound 3, half-maximal inhibitory concentration: 75 nM
Compound 3: middle estimate off by 1.9-fold (0.27 log units), on the low side; low and high end bracket the measured number.
By their numbers in this assay, from the lowest: compounds 1, 2 and 3 (each within the scatter of the next, the first and the last beyond it).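

In this assay, the exchange of thiophen-2-yl for its isomer thiophen-3-yl, on the aromatic carbon next to the ring nitrogen, gives a 1.9-fold higher number from compound 2 to compound 3 (0.27 log units; within the scatter) and so does not separate the two compounds, although they differ only in how the same atoms are joined. The position does now give its first step beyond the scatter, a 2.1-fold higher number from compound 1 to compound 3 (0.32 log units; beyond the scatter) in a modest step for thiophen-3-yl in place of 3-fluorophenyl, whereas thiophen-2-yl in place of 3-fluorophenyl gave a 1.1-fold higher number from compound 1 to compound 2 (0.05 log units; within the scatter) and stayed within it. No supporting measurement is available to explain either step.

Still open, from the compounds shown here alone, is whether this position accepts groups of a different kind from these aromatic rings, such as a morpholine ring, a primary amine or a carboxylic acid, and whether a furan-2-yl and furan-3-yl pair would read as closely as the two thiophene isomers do. Going by these compounds, it is also open whether the small step between the thiophene isomers would persist on a different core or in a read-out other than this assay.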